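The source may report more compounds than this note shows. Statements on the series, on what has been measured and on what is new or still open speak of the compounds shown alone.

Within the data shown here, compound 3 `NS(=O)(=O)c1ccc(NC(=S)Nc2ccc3ncnc(Nc4cccc(Cl)c4F)c3c2)cc1` stands highest of the three numbers so far in a functional assay on NCI-H1975 cells (Homo sapiens) for antiproliferative activity, read by MTT assay, with a stated time of 72 h (on this read-out higher numbers stand for weaker inhibition and lower numbers for stronger inhibition), where compound 3 gives 25100 nM. Its nearest neighbour is compound 2 `NS(=O)(=O)c1ccc(NC(=S)Nc2ccc3ncnc(Nc4ccc(C(F)(F)F)cc4)c3c2)cc1`, which in this assay gives 17100 nM, and the furthest is compound 1 `NS(=O)(=O)c1ccc(NC(=S)Nc2ccc3ncnc(Nc4cccc(Br)c4)c3c2)cc1`, which gives 11000 nM. The step of a 1.5-fold higher number from compound 2 to compound 3 (0.17 log units; within the scatter) is within the scatter, whereas the step of a 2.3-fold higher number from compound 1 to compound 3 (0.36 log units; beyond the scatter) is modest but beyond it; the step of a 1.6-fold higher number from compound 1 to compound 2 (0.19 log units; within the scatter) is within the scatter.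

Compound 4 `NS(=O)(=O)c1ccc(NC(=S)Nc2ccc3ncnc(Nc4cccc(F)c4)c3c2)cc1` differs from compound 3 by 3-fluorophenyl in place of 3-chloro-2-fluorophenyl on a nitrogen on an aromatic ring. This change bears most on the step from compound 1 to compound 3, since the 3-fluorophenyl group, like the 3-bromophenyl group of compound 1, carries a single halogen and drops the second one; that step was a 2.3-fold higher number from compound 1 to compound 3 (0.36 log units; beyond the scatter). A partial reversal of that step is therefore expected, so that compound 4 is estimated to show a 1.7-fold lower number from compound 3 to compound 4 (0.22 log units; within the scatter) in this assay, a step of a size near the edge of the scatter. Compound 4 is accordingly expected to give about 15000 nM in this assay, with a plausible range from 6000 nM to 40000 nM.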

Compound 4, half-maximal inhibitory concentration: 9660 nM
Compound 4: the middle estimate sits 1.6-fold (0.19 log units) above what was measured; the range from low to high includes it.
By their numbers in this assay, from the lowest: compounds 4, 1, 2 and 3 (each within the scatter of the next, the first and the last beyond it).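

In this assay, the 3-fluorophenyl group in place of the 3-chloro-2-fluorophenyl group gives a 2.6-fold lower number from compound 3 to compound 4 (0.41 log units; beyond the scatter), so this position separates compound 3 from compound 4 by a modest step beyond the scatter. Fluoro in place of bromo on an aromatic carbon gives a 1.1-fold lower number from compound 1 to compound 4 (0.06 log units; within the scatter), and the 3-fluorophenyl group in place of 4-(trifluoromethyl)phenyl gives a 1.8-fold lower number from compound 2 to compound 4 (0.25 log units; within the scatter), so neither change can be read as a real difference. No measurement is available to explain these results.

The compounds shown leave open whether the chloro or the fluoro of the 3-chloro-2-fluorophenyl group accounts for the gap to compound 4. They also leave open how an amine or a carboxylic acid on the phenyl group would read in this assay.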